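Moving the Chlorine: 4-Chlorophenyl to 2-Chlorophenyl

The source may report more compounds than this note shows. Statements on the series, on what has been measured and on what is new or still open speak of the compounds shown alone.

- compound 1 `CCOC(=O)N1CCN(Cc2c(O)c([C@H]3CCN(C)C[C@H]3O)c3oc(C)cc(=O)c3c2O)CC1` gives 1%
- compound 2 `COc1ccc(C(O)c2c(C)oc3c([C@H]4CCN(C)C[C@H]4O)c(O)cc(O)c3c2=O)cc1Br` gives 0%
- compound 3 `CN1CC[C@H](c2c(O)cc(O)c3c(=O)cc(/C=C/c4ccc(Cl)cc4)oc23)[C@H](O)C1` gives 12%

In a functional assay on PC-3 cells (Homo sapiens) for inhibition, read by MTT assay, with a stated time of 48 h, tested at 10 uM (a higher number here means more inhibition of growth at the concentration tested, a lower number less inhibition of growth), compound 3 stands highest of the three, beyond the scatter from both compound 1 and compound 2. Compound 4 `CN1CC[C@H](c2c(O)cc(O)c3c(=O)cc(/C=C/c4ccccc4Cl)oc23)[C@H](O)C1` has the same atoms joined differently (2-chlorophenyl in place of 4-chlorophenyl on a double-bonded chain carbon bound to a double-bonded chain carbon) with 2-chlorophenyl in place of 4-chlorophenyl on a double-bonded chain carbon bound to a double-bonded chain carbon. Going by the values given here, no measured pair here differs in one place, so the expectation rests on compound 3 (12%) alone. The expected result is a number 2 percentage points lower from compound 3 to compound 4 (within the scatter) in this assay and thus no step beyond the scatter. Compound 4 is estimated at 10% with an expected range of 0% to 24% in this assay.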

Compound 4, percent growth inhibition at one concentration: 22%
For compound 4 the middle estimate is 12 percentage points below the measured one; measured number inside the range.
By their numbers in this assay, from the lowest: compounds 2 and 1 (each within the scatter of the next); then compounds 3 and 4 (each within the scatter of the next).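

In this assay the change from 4-chlorophenyl to 2-chlorophenyl on a double-bonded chain carbon bound to a double-bonded chain carbon is a number 10 percentage points higher from compound 3 to compound 4 (within the scatter) and so the two placements of the chlorine cannot be told apart. Going by these compounds alone, this is the first comparison that differs in one place, and it shows that this change brings no step beyond the scatter. No evidence on the cause of this result is available. Still open, as far as these compounds go, is whether an amine or a carboxylic acid in place of the chlorine would give a step beyond the scatter.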